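Terminal amine exchanges on a shared core

The source may hold more compounds than are shown below. What is called first, only, known or untested is meant among the compounds shown, and "the series" means these compounds.

Three compounds share one core and differ only in the amine at the far end of the side chain. Compound 1 `C[C@H](CCCN1CCN(C)CC1)Nc1ccnc2cc(Cl)ccc12` carries a 4-methylpiperazin-1-yl group there and gives 180000 nM in an assay for binding affinity, read by spectrophotometry; on this read-out lower numbers stand for stronger inhibition and higher numbers for weaker inhibition. Compound 2 `C[C@H](CCCN1CCCCC1)Nc1ccnc2cc(Cl)ccc12` bears a piperidin-1-yl group and gives 130000 nM in this assay. Compound 3 `C[C@H](CCCN(C)C)Nc1ccnc2cc(Cl)ccc12` has a dimethylamino group and gives 190000 nM in this assay; this is the highest of the three numbers, yet its gaps to the others stay within the scatter, namely a 1.1-fold higher number from compound 1 to compound 3 (0.02 log units; within the scatter) and a 1.5-fold higher number from compound 2 to compound 3 (0.16 log units; within the scatter). The remaining pair also stays within the scatter, with a 1.4-fold lower number from compound 1 to compound 2 (0.14 log units; within the scatter).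

Compound 4 `C[C@H](CCCNC(C)(C)C)Nc1ccnc2cc(Cl)ccc12` has not yet been measured. It differs from compound 3 by (tert-butyl)amino in place of dimethylamino on a saturated chain carbon, four bonds along the chain from a nitrogen on an aromatic ring. The earlier exchanges at this same position all bear on the change, and none of them moved this assay beyond the scatter, whether a ring was swapped for another ring or a ring for an open dimethylamino group. On that basis the expected step is a 1.1-fold lower number from compound 3 to compound 4 (0.02 log units; within the scatter), which amounts to no movement beyond the scatter. Compound 4 is expected at 180000 nM, within a range from 90000 nM to 360000 nM.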

Compound 4, half-maximal inhibitory concentration: 170000 nM
Compound 4: the middle estimate sits 1.1-fold (0.02 log units) above what was measured; low and high end bracket the measured number.
By their numbers in this assay, from the lowest: compounds 2, 4, 1 and 3 (each within the scatter of the next).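

Among these compounds, the (tert-butyl)amino group is the first at this position, on a saturated chain carbon, four bonds along the chain from a nitrogen on an aromatic ring, to carry a hydrogen-bond donor, yet this assay shows no movement beyond the scatter, with a 1.1-fold lower number from compound 3 to compound 4 (0.05 log units; within the scatter) for the exchange of dimethylamino. The open branched amine also stays within the scatter of both ring-bearing compounds, with a 1.3-fold higher number from compound 2 to compound 4 (0.12 log units; within the scatter) and with a 1.1-fold lower number from compound 1 to compound 4 (0.02 log units; within the scatter) as well, so all four terminal groups shown now fall within the scatter of one another, and no compound here goes against that. Nothing available gives a reason for this lack of movement.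

The compounds shown leave open whether a terminal carboxylic acid or an amide in place of the amine would move the number beyond the scatter, and the same holds for a primary amine. They also leave open what a longer chain or a shorter chain between the terminal group and the shared core would do in this assay.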